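Benzyl for cyclopropyl on the side-chain carbon

The source may hold more compounds than are shown below. What is called first, only, known or untested is meant among the compounds shown, and "the series" means these compounds.

Of the compounds shown here, two have been measured in an assay on membranes from Chem-1 cells for displacement of a labelled ligand from prostaglandin E2 receptor EP3 subtype (Homo sapiens), read by scintillation counting, with a stated time of 2 h; a lower number here means a stronger inhibitor, a higher number a weaker inhibitor. Compound 1 `O=C1NC(=O)/C(=C/C(c2ccc(-c3ccc4cccc(F)c4c3)[nH]c2=O)C2CC2)O1` gives 22 nM in this assay. Going by the values given here, the only other number is that of compound 2 `CC(C)C(/C=C1\SC(=O)NC1=O)c1ccc(-c2ccc3cccc(F)c3c2)[nH]c1=O`, which in this assay gives 13 nM; the two values lie within the usual scatter of each other, so no order can be read between them. Among the compounds with values here, compound 1 therefore stands in the same region as the one compound beside it, with nothing in the set that is clearly apart from it.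

Compound 3 `O=C1NC(=O)/C(=C/C(Cc2ccccc2)c2ccc(-c3ccc4cccc(F)c4c3)[nH]c2=O)O1` has not been measured. It differs from compound 1 in one place: benzyl in place of cyclopropyl on a saturated chain carbon bound to an aromatic carbon and a double-bonded chain carbon. Within the data shown here, no measured pair with this change is available. With the two measured compounds sitting close together despite different groups at that carbon, the step from compound 1 to compound 3 is expected to be small, and is estimated at a 1.2-fold lower number from compound 1 to compound 3 (0.09 log units; within the scatter), not beyond the scatter in either direction. For compound 3 the estimated value is 18 nM, with a range of 6 nM to 55 nM.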

Compound 3, inhibition constant in the prostaglandin E2 receptor EP3 subtype assay: 33 nM
Compound 3: the middle estimate sits 1.8-fold (0.26 log units) below what was measured; the measured number falls inside the stated range.
By their numbers in the prostaglandin E2 receptor EP3 subtype assay, from the lowest: compounds 2, 1 and 3 (each within the scatter of the next, the first and the last beyond it).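

Going by these compounds alone, until now the series offered no one-place step at this carbon; the benzyl-for-cyclopropyl change provides the first. At the saturated chain carbon bound to an aromatic carbon and a double-bonded chain carbon, going from cyclopropyl, 3 heavy atoms, to benzyl, 7 heavy atoms with a six-membered aromatic ring, produces no change that can be told apart in the prostaglandin E2 receptor EP3 subtype assay: a 1.5-fold higher number from compound 1 to compound 3 (0.18 log units; within the scatter). In a physicochemical assay for solubility, measured as kinetic solubility, at pH 2 (on this read-out higher numbers stand for higher solubility and lower numbers for lower solubility), compound 1 gives 3850 nM and compound 3 gives 900 nM on this read-out. The same pair does separate in the physicochemical assay, so for these two compounds the solubility read-out, not the receptor read-out, distinguishes the groups: the measured solubility of compound 1, 3850 nM, and of compound 3, 900 nM, a 4.3-fold lower number (0.63 log units; beyond the scatter)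

Still open, going by these compounds, is whether a cyclohexylmethyl or phenyl group at this carbon would follow benzyl in both read-outs, which would help separate the contribution of the aromatic ring from that of the added carbons. Also open, on these data alone, is whether an amine, a carboxylic acid or a longer chain on the same carbon would give a step beyond the scatter at the receptor, or would shift solubility in the opposite direction from benzyl.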